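Shortening the Chain on the Aromatic Nitrogen

A few compounds are considered here, and "the series" means these few. Any claim that something is new, unique, unknown or untested is made for them only; others in the source may bear on it.

Measured so far:
compound 1, `CCCc1c(OCCCCOc2ccc(-c3nn[nH]n3)cc2)ccc2c1ccn2CC(C)(C)C`: 559 nM
compound 2, `CCCc1c(OCCCCOc2ccc(-c3nn[nH]n3)cc2)ccc2c1cnn2CC(C)(C)C`: 984 nM

In a functional assay for binding affinity to metabotropic glutamate receptor 2 (Homo sapiens), read by GTPgammaS binding, with a stated time of 1 h, at 30 degrees C (a lower number here means that less compound is needed, a higher number that more compound is needed for the effect), compound 1 gives 559 nM, the lower of the two numbers. Compound 2 gives 984 nM, and the gap between the two lies within the usual scatter of repeated measurements, so neither can be ranked above the other. Compound 3, `CCCc1c(OCCCCOc2ccc(-c3nn[nH]n3)cc2)ccc2c1ccn2CCC`, differs from compound 1 in one place: ethyl in place of tert-butyl on a saturated chain carbon bound to an aromatic nitrogen. Going by the values given here, no measured pair shows this change, so there is no step to lean on. Only a small step is expected, if any, perhaps a slight rise in the number. Compound 3 is estimated at 800 nM, with a range from 250 nM to 2500 nM. The expected step is a 1.4-fold higher number from compound 1 to compound 3 (0.16 log units; within the scatter).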

Compound 3, half-maximal effective concentration: 652 nM
For compound 3 the middle estimate is 1.2-fold (0.09 log units) above the measured one; the measured number falls inside the stated range.
By their numbers in this assay, from the lowest: compounds 1, 3 and 2 (each within the scatter of the next).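

Cutting neopentyl to propyl on the aromatic nitrogen gives the first direct reading of this position: in this assay the change is a 1.2-fold higher number from compound 1 to compound 3 (0.07 log units; within the scatter) and so cannot be told from scatter. In this one pair, the chain on the nitrogen can therefore be shorter with no clear change in the number. No measurement here accounts for this result.

Still open, as far as these compounds go, is how a longer chain, such as octyl, would read at this position. The same goes for a chain ending in an amine or a carboxylic acid.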